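Same aryl swap, tried on a second core

The source may hold more compounds than are shown below. What is called first, only, known or untested is meant among the compounds shown, and "the series" means these compounds.

Compound 1, `COc1ccc(S(=O)(=O)c2cnc3cc(Cl)ccc3c2N2CCC(C)CC2)cc1Cl`, gives 93%.
Compound 2, `COc1cccc(S(=O)(=O)c2cnc3cc(Cl)ccc3c2N2CCC(C)CC2)c1`, gives 93%.
Compound 3, `COc1ccc2ncc(S(=O)(=O)c3ccc(OC)c(Cl)c3)c(N3CCC(C)CC3)c2c1`, gives 21%.

All three were tested in an assay on isolated protein for displacement of a labelled ligand from metabotropic glutamate receptor 5 (Homo sapiens), with a stated time of 60 min, tested at 1 uM; a higher number here means more inhibition at the concentration tested (going by the name of the read-out), a lower number less inhibition. Compound 1 and compound 2 share one core and differ only in the group on the sulfonyl sulfur: 3-methoxyphenyl in place of 3-chloro-4-methoxyphenyl on a sulfonyl sulfur. That swap made no change at the digits printed from compound 1 to compound 2 (within the scatter). Compound 3 carries a different core; the difference between the two cores is not broken down here. In this assay compound 3 stands far lower than compound 1 and compound 2.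

Compound 4, `COc1cccc(S(=O)(=O)c2cnc3ccc(OC)cc3c2N2CCC(C)CC2)c1`, has not yet been measured. It is compound 3 with the same change that turned compound 1 into compound 2: 3-methoxyphenyl in place of 3-chloro-4-methoxyphenyl on a sulfonyl sulfur. The place is the same in both pairs, a sulfonyl sulfur whose other neighbour is an aromatic carbon. Since that change left compound 1 and compound 2 at the same level, the expectation for the step from compound 3 to compound 4 is a similarly flat a number 3 percentage points higher from compound 3 to compound 4 (within the scatter). Compound 4 is therefore expected to give about 24% in this assay, most likely between 8% and 45%.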

Compound 4, a percentage reported as inhibition, at one concentration (the size of the read-out at that concentration, not a potency): 0%
The estimate for compound 4 lay 24 percentage points above the measured number, and the stated range ends above it.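

On the core of compound 3, replacing 3-chloro-4-methoxyphenyl with 3-methoxyphenyl on the sulfonyl sulfur gave, in this assay, a number 21 percentage points lower from compound 3 to compound 4 (beyond the scatter). This comparison rests on a single pair on each core, so it offers no general rule for the series and does not explain why the two pairs behave differently. Even so, it shows that the result of this change did not carry over unaltered from one core to the other: the same change on two cores in this assay, no change at the digits printed (within the scatter) from compound 1 to compound 2 and a number 21 percentage points lower (beyond the scatter) from compound 3 to compound 4, 21 percentage points apart, beyond the scatter of two such steps

As far as these compounds go, it remains open whether other groups on the sulfonyl sulfur, such as a plain phenyl or a phenyl bearing an amine, would also separate the two cores in this way. From the compounds shown here alone, these percentages at one concentration are also not potencies, so the potency of each of the four compounds remains open too.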